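Replacing bromine with two fluorines on the anilide ring

A few compounds are considered here, and "the series" means these few. Any claim that something is new, unique, unknown or untested is made for them only; others in the source may bear on it.

Measured so far:
- Compound 1, `CN1C[C@H](C(=O)Nc2ccccc2)[C@@H](c2ccc(/C=C/C(=O)Nc3ccccc3N)cc2)C1`: 67 mL/min/kg
- Compound 2, `CN1C[C@H](C(=O)Nc2ccc(Br)cc2)[C@@H](c2ccc(/C=C/C(=O)Nc3ccccc3N)cc2)C1`: 16 mL/min/kg
- Compound 3, `CN1C[C@H](C(=O)Nc2ccc(F)c(Br)c2)[C@@H](c2ccc(/C=C/C(=O)Nc3ccccc3N)cc2)C1`: 43 mL/min/kg

In an in vitro ADME assay on microsomes from liver (Mus musculus) for pharmacokinetics, read by LC-MS, with a stated time of 10 min, tested at 1 uM (a lower number here means slower removal, a higher number faster removal of the compound), compound 2 gives the lowest of the three numbers; its nearest neighbour is compound 3, a 2.7-fold higher number from compound 2 to compound 3 (0.43 log units; beyond the scatter), and its furthest is compound 1, a 4.2-fold lower number from compound 1 to compound 2 (0.62 log units; beyond the scatter) (read in the other direction). Compound 4, `CN1C[C@H](C(=O)Nc2ccc(F)cc2F)[C@@H](c2ccc(/C=C/C(=O)Nc3ccccc3N)cc2)C1`, has not been measured. It differs from compound 2 in one place: 2,4-difluorophenyl in place of 4-bromophenyl on an amide-type nitrogen.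

Going by the values given here, two measured steps bear on this. The step of a 4.2-fold lower number from compound 1 to compound 2 (0.62 log units; beyond the scatter) shows that bromo in place of hydrogen on the aromatic carbon gave a clearly lower number. The step of a 2.7-fold higher number from compound 2 to compound 3 (0.43 log units; beyond the scatter) shows that moving to 3-bromo-4-fluorophenyl, which keeps the bromine, still gave a higher number than compound 2. Compound 4 gives up the bromine altogether and takes on 2,4-difluorophenyl, so the account expects the number in this assay to move back up toward compound 1, by a modest step, a 2.8-fold higher number from compound 2 to compound 4 (0.45 log units; beyond the scatter).

For compound 4 the estimated clearance in this assay is 45 mL/min/kg, with a range from 22 mL/min/kg to 90 mL/min/kg.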

Compound 4, clearance: 27 mL/min/kg
Compound 4: middle estimate off by 1.7-fold (0.22 log units), on the high side, within the range that was stated.
By their numbers in this assay, from the lowest: compounds 2, 4, 3 and 1 (each within the scatter of the next, the first and the last beyond it).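

In this assay, going by these compounds alone, bromo had so far been the only change on this aryl group to give a step beyond the scatter from the unsubstituted phenyl, but 2,4-difluorophenyl on the amide-type nitrogen, which carries no bromine, does so as well, with a 2.5-fold lower number from compound 1 to compound 4 (0.39 log units; beyond the scatter). Set against the two bromine-bearing groups, the change stays within the scatter, with a 1.7-fold higher number from compound 2 to compound 4 (0.23 log units; within the scatter) and a 1.6-fold lower number from compound 3 to compound 4 (0.20 log units; within the scatter), so bromine is not needed at this position for a number clearly apart from that of compound 1, and compound 3, with a 1.6-fold lower number from compound 1 to compound 3 (0.19 log units; within the scatter), shows that a bromine on the ring does not ensure one either. Nothing measured here explains this behaviour of the ring substituents.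

Going by these compounds, what a single fluorine would give on this ring stays open, and so does the question of whether both fluorines of compound 4 contribute to its separation from compound 1. On these data alone, it is also open how a chloro, methoxy or trifluoromethyl group at this position would compare, and the steps among compound 2, compound 4 and compound 3 are too small to rank these groups.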